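A few compounds are considered here, and "the series" means these few. Any claim that something is new, unique, unknown or untested is made for them only; others in the source may bear on it.

Three compounds that share one core were tested in a functional assay on THP-1 cells (Homo sapiens) for inhibition, read by sulforhodamine B assay, with a stated time of 48 h; on this read-out lower numbers stand for stronger inhibition and higher numbers for weaker inhibition. Compound 1 `COc1ccc(/C(=N/O)c2cccc3ccccc23)c(OC)c1OC` is the starting point of the step followed here. In this assay compound 1 reaches only the limit of the measurement, > 20000 nM, so no true number is known for it. Compound 2 `COc1ccc(C(c2ccc(OC(C)CN(C)C)cc2)c2cccc3ccccc23)c(OC)c1OC` gives 15000 nM in this assay. Compound 3 `COc1ccc(C(O)(Cc2ccc(C)cc2)c2cccc3ccccc23)c(OC)c1OC` likewise reaches only the limit of the measurement, > 20000 nM, in this assay. Taken together, the limit of > 20000 nM in this assay, at which 2 of the 3 values shown sit, marks where most of what has been measured sits, and compound 1 stands there, known only as a limit rather than as a number.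

Compound 4 `COc1ccc(/C(=N/OC(C)=O)c2cccc3ccccc23)c(OC)c1OC` has not yet been tested. It differs from compound 1 in one place: acetyl in place of hydrogen on an oxygen, which, cut one bond further out, reads as hydroxy to acetoxy. Going by the values given here, no measured pair in this set shows what such a change does, so the expectation rests only on where compound 1 sits. Because compound 1 gives > 20000 nM, a limit, compound 4 is expected to stay in the same weak region, with no step beyond the usual scatter in either direction, and the expected step is a step that the limit leaves unreadable from compound 1 to compound 4. For compound 4 the estimate in this assay is 22000 nM, between 7000 nM and 70000 nM, with a real chance that only a limit is reported again.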

Compound 4, half-maximal inhibitory concentration: > 20000 nM
Compound 4: a limit, no number; the forecaster's own chance of this, stated with the estimate: 55%; the middle value lies beyond the limit too.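

Compound 4 gives > 20000 nM in this assay, which is a limit and not a number. No step can be read from compound 1 to compound 4, as each is known only as a limit: the limit of > 20000 nM in this assay, at which 3 of the 4 values shown sit.

The compounds shown leave open whether acetyl in place of hydrogen on this oxygen changes inhibition at all.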